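This account rests on a few compounds, and the source may have more. Where it says the series, first, only, none or still open, it means among the compounds named here.

Working notes on a series of amide antagonists sharing the core of compound 2. In an assay on CHO cells for antagonist activity at transient receptor potential cation channel subfamily V member 1 (Homo sapiens), read by FLIPR (a lower number here means a stronger inhibitor, a higher number a weaker inhibitor), compound 1 `COc1ccc(N2CCN(c3cc(C(F)(F)F)ccc3CNC(=O)C(C)c3ccc(NS(C)(=O)=O)c(F)c3)CC2)cc1` gives 1.6 nM, compound 2 `CC(C(=O)NCc1ccc(C(F)(F)F)cc1OC1CCCCC1)c1ccc(NS(C)(=O)=O)c(F)c1` gives 0.7 nM and compound 3 `C[C@@H](C(=O)NCc1ccc(C(F)(F)F)cc1SC1CCCCC1)c1ccc(NS(C)(=O)=O)c(F)c1` gives 13.9 nM. Compound 2 holds the lowest number of the three; compound 1 sits nearest, beyond the scatter, and compound 3 furthest, also beyond the scatter. Compound 4 `CC(C(=O)NCc1ccc(C(F)(F)F)cc1-c1cccc(Cl)c1)c1ccc(NS(C)(=O)=O)c(F)c1` is not yet measured. Its change from compound 2: 3-chlorophenyl in place of cyclohexyloxy on an aromatic carbon. Going by the values given here, no measured step covers this pair. For the step of a 7.1-fold higher number from compound 2 to compound 4 (0.85 log units; beyond the scatter) an upward move of moderate size is expected, since compound 3 at 13.9 nM shows how far the number can climb within this series. Compound 4 is therefore estimated at 5 nM, with a range from 1.5 nM to 20 nM.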

Compound 4, inhibition constant: 1 nM
For compound 4 the middle estimate is 5.0-fold (0.70 log units) above the measured one; the whole stated range lies above it.
By their numbers in this assay, from the lowest: compounds 2, 4 and 1 (each within the scatter of the next, the first and the last beyond it); then compound 3.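

In this assay, putting 3-chlorophenyl in place of cyclohexyloxy gives a 1.4-fold higher number from compound 2 to compound 4 (0.15 log units; within the scatter). This position on the aromatic ring therefore takes either a non-aromatic ring linked through oxygen or a directly attached chlorinated aromatic ring, and losing the hydrogen-bond acceptor of cyclohexyloxy brings no change beyond the scatter. No supporting evidence is available to explain this result.

Still open, from the compounds shown here alone, is how a much smaller group at this position, such as methoxy, would read. Also open, going by these compounds, is whether an amine or a carboxylic acid on the entering phenyl ring would keep the number in this range.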